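The source may hold more compounds than are shown below. What is called first, only, known or untested is meant among the compounds shown, and "the series" means these compounds.

Compound 2 `C[C@]1(C(=O)N2CC[C@](c3ccc(C(F)(C(F)(F)F)C(F)(F)F)cc3)(S(=O)(=O)c3ccc(F)cc3)C2)CC[C@H](C(=O)O)CC1` carries a 4-carboxy-1-methylcyclohexyl group on a carbonyl carbon whose other neighbour is an amide-type nitrogen in a ring. Going by the values given here, in an ADME assay on microsomes from liver (Mus musculus) for metabolic stability, with a stated time of 10 min (on this read-out higher numbers stand for a more stable compound and lower numbers for a less stable compound), compound 2 gives 95%, and this is the only number the set holds. In this assay compound 1 `CC[C@]1(C(=O)O)CC[C@H](C(=O)N2CC[C@](c3ccc(C(F)(C(F)(F)F)C(F)(F)F)cc3)(S(=O)(=O)c3ccc(F)cc3)C2)CC1` gives "not determined" (no result reported). In this assay compound 3 `O=C(O)C12CCC(C(=O)N3CC[C@](c4ccc(C(F)(C(F)(F)F)C(F)(F)F)cc4)(S(=O)(=O)c4ccc(F)cc4)C3)(CC1)C2` gives "not determined" (no result reported). Compound 4 `NC(=O)[C@H]1CC[C@H](C(=O)N2CC[C@](c3ccc(C(F)(C(F)(F)F)C(F)(F)F)cc3)(S(=O)(=O)c3ccc(F)cc3)C2)CC1` has not yet been measured in this assay. It differs from compound 2 in a single place (4-carbamoylcyclohexyl in place of 4-carboxy-1-methylcyclohexyl on a carbonyl carbon). Among the compounds with values here, no measured step exists to lean on, so the expected change from compound 2 to compound 4 is a moderate drop, estimated as a number 15 percentage points lower from compound 2 to compound 4 (beyond the scatter), likely just beyond the scatter. Compound 4 is therefore estimated at 80% in this assay, within a range from 55% to 98%.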

Compound 4, percent of the compound remaining: 100%
The estimate for compound 4 lay 20 percentage points below the measured number, and the stated range ends below it.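

In this assay, going by these compounds alone, 4-carbamoylcyclohexyl in place of 4-carboxy-1-methylcyclohexyl on a carbonyl carbon gives a number 5 percentage points higher from compound 2 to compound 4 (within the scatter) and so provides the first readable step at this place, where the two groups cannot be told apart on this read-out. The change replaces the carboxy group and removes the methyl group in one step, so their separate contributions cannot be read from it. Nothing available explains this result. The compounds shown leave open how an amine or a nitrile in place of the carbamoyl group would read in this assay. They also leave open whether a methyl group added to the ring of the 4-carbamoylcyclohexyl group would alter the reading.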